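Replacing 3,4-Difluorophenyl with 4-Methylphenyl: Expected Inactivity

This account rests on a few compounds, and the source may have more. Where it says the series, first, only, none or still open, it means among the compounds named here.

Compound 1 `Cc1nn(C)c(Oc2ccc(I)cc2)c1/C=N\CCCCCOc1cc2oc(=O)cc(C)c2cc1Cl` and compound 2 `Cc1nn(C)c(Oc2ccc(F)c(F)c2)c1/C=N\CCCCCCOc1cc2oc(=O)cc(C)c2cc1Cl` were tested in a functional assay on HepG2 cells (Homo sapiens) for antiproliferative activity, read by MTT assay, with a stated time of 72 h; on this read-out lower numbers stand for stronger inhibition and higher numbers for weaker inhibition. Compound 1 reaches only the assay limit, > 25000 nM. Compound 2 likewise shows only the limit, > 25000 nM. Both results sit at the limit of > 25000 nM in this assay, at which 2 of the 2 values shown sit, so neither compound shows measurable inhibition here. Compound 3 `Cc1ccc(Oc2c(/C=N\CCCCCCOc3cc4oc(=O)cc(C)c4cc3Cl)c(C)nn2C)cc1` differs from compound 2 by 4-methylphenyl in place of 3,4-difluorophenyl on an oxygen on an aromatic ring. Going by the values given here, no measured step exists for this kind of change, and compound 2 stands at the limit, so the expected step, a step that the limit leaves unreadable from compound 2 to compound 3, is none beyond the scatter. Compound 3 is therefore estimated to give about 30000 nM, within a range from 8000 nM to 100000 nM.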

Compound 3, half-maximal inhibitory concentration: 20700 nM
Estimate against measurement, compound 3: 1.4-fold (0.16 log units) above; the range from low to high includes it.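

In this assay, putting 4-methylphenyl in place of 3,4-difluorophenyl on this oxygen gives an at least 1.2-fold lower number from compound 2 to compound 3 (0.08 log units; that floor lies within the scatter). Compound 3 thus gives a real number rather than a limit, so the change leaves the compound weak but brings its reading into the measurable range. The true size of the step cannot be read because compound 2 stands at a limit: the limit of > 25000 nM in this assay, at which 2 of the 3 values shown sit.

On these data alone, whether an amine or a carboxylic acid in place of the methyl would give a much lower number stays open. So does whether this change would act the same way on other compounds.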